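The source may hold more compounds than are shown below. What is called first, only, known or untested is meant among the compounds shown, and "the series" means these compounds.

Measured so far in an assay on HEK298 cells for displacement of a labelled ligand from D(4) dopamine receptor (Homo sapiens); a lower number here means a stronger inhibitor, a higher number a weaker inhibitor:
compound 1 `O=C(N[C@H]1CCN(Cc2ccc(C(F)(F)F)cc2)C1)c1ccc(-c2cccs2)cc1` gives 14 nM
compound 2 `O=C(N[C@H]1CCN(Cc2ccc(OC(F)(F)F)cc2)C1)c1ccc(-c2cccs2)cc1` gives 78 nM

Within the data shown here, compound 1 holds the lower of these two numbers; the one measured step away from it is a 5.6-fold higher number from compound 1 to compound 2 (0.75 log units; beyond the scatter). Compound 3 `O=C(N[C@H]1CCN(Cc2ccc(Cl)c(Cl)c2)C1)c1ccc(-c2cccs2)cc1` has not been measured. It differs from compound 1 by 3,4-dichlorophenyl in place of 4-(trifluoromethyl)phenyl on a saturated chain carbon bound to an amine nitrogen in a ring. The measured step swaps a different group and so bears only loosely on this change, and it gives no direction for it. Compound 3 is therefore expected to stay near compound 1, with an expected step of a 1.1-fold higher number from compound 1 to compound 3 (0.03 log units; within the scatter). The estimate for compound 3 in this assay is 15 nM, between 4 nM and 60 nM.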

Compound 3, inhibition constant: 15 nM
Estimate against measurement, compound 3: no gap at the digits printed; the range from low to high includes it.
By their numbers in this assay, from the lowest: compounds 1 and 3 (each within the scatter of the next); then compound 2.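

In this assay, 3,4-dichlorophenyl in place of 4-(trifluoromethyl)phenyl gives a 1.1-fold higher number from compound 1 to compound 3 (0.03 log units; within the scatter), so the two compounds read alike. This position can therefore hold a ring with two chlorine atoms instead of one trifluoromethyl group, while compound 2, with trifluoromethoxy, shows that not every replacement here leaves the number unchanged. No measured evidence explains this difference between the replacements.

Still open, from the compounds shown here alone, is whether a ring with a single chlorine would read like compound 3. A methoxy group or an amine on this ring is also untested among the compounds shown.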